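This account rests on a few compounds, and the source may have more. Where it says the series, first, only, none or still open, it means among the compounds named here.

The measured compounds:

Compound 1, `C=CC(=C)[C@@H](O)C[C@H]1C(=C)CC[C@@H]2[C@]1(C)CCC[C@]2(C)C(=O)O`. In a functional assay on SW480 cells (Homo sapiens) for cytotoxicity, read by MTT assay, with a stated time of 48 h (a lower number here means a stronger inhibitor, a higher number a weaker inhibitor), compound 1 gives > 40000 nM, which is a limit of the assay and not a number.

Compound 2, `C=C[C@@](C)(O)CC[C@H]1C(=C)CC[C@@H]2[C@]1(C)CCC[C@]2(C)C(=O)O`. In this assay compound 2 gives > 40000 nM, again a limit of the assay rather than a number.

From the compounds shown here alone, compound 2 therefore stands at the upper edge of what this assay can report; its true value is unknown beyond that limit. For the measured compounds named here, the one measured step, a step that the two limits leave unreadable from compound 1 to compound 2, tells nothing about direction or size, because both of its ends sit at the limit of > 40000 nM in this assay, at which 2 of the 2 values shown sit.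

Compound 3, `C=CC(=C)[C@H](O)C[C@H]1C(=C)CC[C@@H]2[C@]1(C)CCC[C@]2(C)C(=O)O`, is the next compound, not yet measured. It differs from compound 2 by a group of 6 heavy atoms (5 carbon, 1 oxygen; no ring) in place of a group of 6 heavy atoms (5 carbon, 1 oxygen; no ring), on a saturated chain carbon bound to a saturated ring carbon. Going by the values given here, the single measured step bears on this change only in that it shows no movement readable from the limit; there is no measured step of known size to set an expectation for this assay in either direction.

Compound 3 is therefore expected to give about 60000 nM in this assay, within a range of 20000 nM to 200000 nM. The step that the limit leaves unreadable from compound 2 to compound 3 is an estimate that most likely again ends at the limit rather than at a measured number.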

Compound 3, half-maximal inhibitory concentration: > 40000 nM
Compound 3: no number, only a limit (the forecaster's own chance of this, stated with the estimate: 85%); the middle value does not contradict the limit.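

For the compounds shown here, compound 3 sits with compound 1 and compound 2 at the limit of the assay, which is not a number, so no step among the three can be read: the limit of > 40000 nM in this assay, at which 3 of the 3 values shown sit. The compounds shown leave open how far each lies past that limit, and whether the stereocentre at the saturated chain carbon or the changed group affects cytotoxicity at all.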